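One Aryl Swap and an Uncertain Expectation

The compounds below may be only part of what the source reports. "The series", "measured", "known", "first", "only" and "open" are said of these compounds alone.

compound 1 `Cc1nn(-c2nc(-c3ccc(Cl)c(Cl)c3)c(SC(C)C)s2)c(C(=O)O)c1-c1cccc(F)c1`: 900 nM
compound 2 `Cc1nn(-c2nc(-c3ccc(Cl)c(Cl)c3)c(SC(C)C)s2)c(C(=O)O)c1-c1cccc(Cl)c1`: 13600 nM

For the measured compounds named here, in a functional assay on BJAB cells (Homo sapiens) for antiproliferative activity, with a stated time of 4 days (on this read-out higher numbers stand for an effect only at larger amounts of compound and lower numbers for an effect already at smaller amounts), compound 2 gives the highest number of the two measured compounds; the single measured step, a 15-fold higher number from compound 1 to compound 2 (1.18 log units; beyond the scatter), was large. Compound 3 `Cc1nn(-c2nc(-c3ccc(Cl)c(Cl)c3)c(SC(C)C)s2)c(C(=O)O)c1-c1cc(C#N)cc(C(F)(F)F)c1` carries the change (3-cyano-5-(trifluoromethyl)phenyl in place of 3-chlorophenyl on an aromatic carbon). Going by the values given here, no measured step involves either of the groups that enter, so the halogen swap is only a loose guide and the expectation is wide. The step expected is a 1.4-fold lower number from compound 2 to compound 3 (0.13 log units; within the scatter), with no clear direction beyond the scatter. Compound 3 is estimated at 10000 nM, with a range from 1500 nM to 60000 nM.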

Compound 3, half-maximal effective concentration: 3600 nM
The estimate for compound 3 lay 2.8-fold (0.44 log units) above the measured number, and the stated range covers the measured number.
By their numbers in this assay, from the lowest: compound 1; then compound 3; then compound 2.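

At this position a ring carrying two groups is not ruled out: in this assay the change to 3-cyano-5-(trifluoromethyl)phenyl brings a 3.8-fold lower number from compound 2 to compound 3 (0.58 log units; beyond the scatter) and so partly reverses the loss seen with 3-chlorophenyl. It still falls short of 3-fluorophenyl, with a 4.0-fold higher number from compound 1 to compound 3 (0.60 log units; beyond the scatter) in this series, so the largest entering group gives neither the lowest nor the highest number. Nothing available here explains these steps.
Still open, on these data alone, is whether the nitrile or the trifluoromethyl alone drives the change, and how a methoxy group or an amine on this ring would compare.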